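Compound 2 and its methoxy counterpart, compound 4

The compounds below may be only part of what the source reports. "The series", "measured", "known", "first", "only" and "open" are said of these compounds alone.

Measured in a physicochemical assay for solubility, using the shake flask method, in phosphate buffer, with a stated time of 90 min, at pH 6.8; on this read-out higher numbers stand for higher solubility and lower numbers for lower solubility:
compound 1 (`COc1cc(/C=C/C(=O)/C=C(/C=C/c2ccc(O)c(OC)c2)NCCO)ccc1O`) gives 8140 nM
compound 2 (`COc1cc(/C=C/C(=O)/C=C(/C=C/c2ccc(O)c(OC)c2)NCCCO)ccc1O`) gives 25400 nM
compound 3 (`COCCNC(=C\C(=O)/C=C/c1ccc(O)cc1)/C=C/c1ccc(O)cc1`) gives 37500 nM

Among these three, compound 2 at 25400 nM lies within the scatter of compound 3 at 37500 nM and sits clearly apart from compound 1. Compound 4 (`COCCCNC(=C\C(=O)/C=C/c1ccc(O)c(OC)c1)/C=C/c1ccc(O)c(OC)c1`) has not yet been measured. It differs from compound 2 by methyl in place of hydrogen on an oxygen on a saturated carbon in a change of hydroxymethyl to methoxymethyl, that is, methyl in place of hydrogen on an oxygen on a saturated carbon.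

Within the data shown here, no measured step shows this change directly. The closest is a 3.1-fold higher number from compound 1 to compound 2 (0.49 log units; beyond the scatter) as hydroxymethyl replaces hydroxy on a saturated chain carbon, a modest step of another kind. Compound 3 does carry 2-methoxyethyl, but on a different core, so its 37500 nM isolates no effect of the methyl. The data therefore support no direction, and no shift beyond the scatter is expected. The expected step is a 1.2-fold lower number from compound 2 to compound 4 (0.06 log units; within the scatter) on this estimate. For compound 4 the estimated value in this assay is 22000 nM with an expected range from 9000 nM to 55000 nM for repeated measurements.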

Compound 4, solubility: 7700 nM
Beside the measured number, compound 4's estimate is 2.9-fold (0.46 log units) above it; the whole stated range lies above it.
By their numbers in this assay, from the lowest: compounds 4 and 1 (each within the scatter of the next); then compounds 2 and 3 (each within the scatter of the next).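

In this assay, among these compounds, the change of hydroxymethyl to methoxymethyl gives a 3.3-fold lower number from compound 2 to compound 4 (0.52 log units; beyond the scatter) and so provides the first direct reading of methyl in place of hydrogen on this oxygen: at this position, the change is not silent. Methoxymethyl in place of hydroxy gives a 1.1-fold lower number from compound 1 to compound 4 (0.02 log units; within the scatter) on the same core, so the rise seen in a 3.1-fold higher number from compound 1 to compound 2 (0.49 log units; beyond the scatter) does not survive once the oxygen carries methyl, and the added chain carbon alone does not set the read-out for this pair of compounds. No measurement bearing on why the methyl has this effect is available here.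

The compounds shown leave open whether methyl on this oxygen gives a step of similar size on the core of compound 3, since no hydroxy partner of compound 3 stands beside it. They also leave open how an amine or a carboxylic acid in place of the hydroxymethyl, or a longer chain ending in hydroxy or methoxy, would read in this position.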